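A few compounds are considered here, and "the series" means these few. Any claim that something is new, unique, unknown or untested is made for them only; others in the source may bear on it.

This set of compounds shares one core, and the readings come from a functional assay on HeLa cells (Homo sapiens) for inhibition, with a stated time of 72 h; a lower number here means that less compound is needed, a higher number that more compound is needed for the effect. Compound 1 `COc1cc(CNCc2ccccc2)ccc1OCc1ccc(Cl)nc1` gives 90000 nM in this assay. Compound 2 `COc1cc(CNCc2ccncc2)ccc1OCc1ccc(F)cc1` gives 6400 nM in this assay, and of the two numbers it is the lower one; the gap to compound 1 lies beyond the usual scatter of repeated measurements. Compound 3 `COc1cc(CNC2CCCCC2)ccc1OCc1ccc(Cl)nc1` is recorded as "nd(insoluble)" (no result reported) in this assay, which means that no number was obtained; the only note is that it was insoluble. Compound 2 therefore stands at the low end of what has been measured, with compound 1 well above it and nothing else to compare.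

The next compound, compound 4 `COc1cc(CNCc2ccncc2)ccc1OCc1ccc(Cl)cc1Cl`, differs from compound 2 in one place: 2,4-dichlorophenyl in place of 4-fluorophenyl on a saturated chain carbon bound to an oxygen on an aromatic ring. Put another way, a 4-fluorobenzyl group becomes a 2,4-dichlorobenzyl group on the oxygen side of the core.

Going by the values given here, no measured pair shows what such a swap does in this assay, so the expectation rests on compound 2 alone. The step from compound 2 to compound 4 is expected to be small, a 1.6-fold lower number from compound 2 to compound 4 (0.20 log units; within the scatter), likely within or just past the scatter. For compound 4 the expected value in this assay is 4000 nM, with a plausible range from 1500 nM to 15000 nM.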

Compound 4, half-maximal effective concentration: 3900 nM
For compound 4 the middle estimate is 1.0-fold (0.01 log units) above the measured one; the measured number falls inside the stated range.
By their numbers in this assay, from the lowest: compounds 4 and 2 (each within the scatter of the next); then compound 1.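

In this assay, going by these compounds alone, the swap of 4-fluorophenyl for 2,4-dichlorophenyl gives the first step between measured compounds that differ in one place: a 1.6-fold lower number from compound 2 to compound 4 (0.22 log units; within the scatter). This step means that, at this place on the core, on a saturated chain carbon bound to an oxygen on an aromatic ring, a ring carrying chlorine can stand in for one carrying fluorine with no change that can be told apart from repeat-measurement noise, at least with the pyridine-bearing amine side of compound 2 held fixed. Nothing measured here explains why the reading holds steady under this change.

Within the data shown here, the single step also changes the halogen and the pattern of substitution together, so it cannot show what each contributes, and it cannot say whether a plain phenyl with no halogen, a carboxylic acid on the ring or a longer chain before the ring would move the number. Going by these compounds, whether the same swap would behave alike with the benzyl or cyclohexyl amine side seen in compound 1 and compound 3 also stays open.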